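Pyrazole-urea series: phenyl substituent variation on the ring nitrogen

The compounds below may be only part of what the source reports. "The series", "measured", "known", "first", "only" and "open" are said of these compounds alone.

Compound 2 `CC(C)(C)c1cc(CNC(=O)Nc2cccc3[nH]ncc23)n(-c2cccc(C(F)(F)F)c2)n1` holds the lowest number in an assay on CHO-K1 cells for antagonist activity at transient receptor potential cation channel subfamily V member 1 (Homo sapiens), read by FLIPR and calcium flux, with a stated time of 6 min (on this read-out higher numbers stand for weaker inhibition and lower numbers for stronger inhibition), giving 0.3 nM; compound 1 `CC(C)(C)c1cc(CNC(=O)Nc2cccc3[nH]ncc23)n(-c2cccc(F)c2)n1` gives 1.3 nM in this assay. Going by the values given here, the only step measured, a 4.3-fold lower number from compound 1 to compound 2 (0.64 log units; beyond the scatter), was a trifluoromethyl in place of fluoro on an aromatic carbon, modest in size. Compound 3 `CC(C)(C)c1cc(CNC(=O)Nc2cccc3[nH]ncc23)n(-c2ccc(F)cc2)n1` carries 4-fluorophenyl in place of 3-(trifluoromethyl)phenyl on an aromatic nitrogen. Among the compounds with values here, no measured step covers this change; the trifluoromethyl is removed and the fluoro sits elsewhere, so a reversal of roughly the size seen from compound 1 to compound 2 is expected, a weakening a 6.7-fold higher number from compound 2 to compound 3 (0.82 log units; beyond the scatter). Compound 3 is estimated at 2 nM, range 0.5 nM to 8 nM.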

Compound 3, inhibition constant: 2.2 nM
Compound 3: middle estimate off by 1.1-fold (0.04 log units), on the low side, and the stated range covers the measured number.
By their numbers in this assay, from the lowest: compound 2; then compounds 1 and 3 (each within the scatter of the next).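

In this assay, 4-fluorophenyl on the aromatic nitrogen gives up the advantage of 3-(trifluoromethyl)phenyl, with a 7.3-fold higher number from compound 2 to compound 3 (0.87 log units; beyond the scatter). Moving the fluoro alone gives a 1.7-fold higher number from compound 1 to compound 3 (0.23 log units; within the scatter), so the two fluorophenyl compounds cannot be separated here, and compound 2 stands apart from both. No measured evidence bears on the reason for this difference.

The compounds shown leave open how an unsubstituted phenyl, or a phenyl bearing a methoxy group or an amine, would compare at this position. From the compounds shown here alone, the effect of replacing the tert-butyl group also remains open.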